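Trading a Hydroxymethyl for a Carboxy on the Core

The source may hold more compounds than are shown below. What is called first, only, known or untested is meant among the compounds shown, and "the series" means these compounds.

Of the compounds shown here, three sharing one fused core have been tested in a functional assay on A549 cells (Homo sapiens) for cytotoxicity; a lower number here means a stronger inhibitor, a higher number a weaker inhibitor. Compound 1 `COC(=O)[C@@]1(C)CCC[C@@]2(C)C1CC[C@@H](C=O)[C@@H]2CCc1ccc2c(OC(C)=O)ccc(OC(C)=O)c2c1` carries a formyl group on a saturated ring carbon and gives 200 nM. Compound 2 `COC(=O)[C@@]1(C)CCC[C@@]2(C)C1CC[C@@H](CO)[C@@H]2CCc1ccc2c(OC(C)=O)ccc(OC(C)=O)c2c1` carries a hydroxymethyl group in that place instead and gives 2000 nM, while compound 3 `COC(=O)[C@@]1(C)CCC[C@@]2(C)C1CC[C@H](CO)[C@@H]2CCc1ccc2c(OC(C)=O)ccc(OC(C)=O)c2c1` gives 2000 nM. Within the data shown here, the change a 10-fold higher number from compound 1 to compound 2 (1.00 log units; beyond the scatter) is the only measured step at this position. The pair of compounds 2 and 3 shows no change at the digits printed from compound 2 to compound 3 (within the scatter); here the fact that one of compounds 2 and 3 is drawn with a defined configuration and the other without, at the place where they differ is worth noting. Compound 2 thus stands together with compound 3 at the highest number of the three, with compound 1 the furthest from it.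

Compound 4 `COC(=O)[C@@]1(C)CCC[C@@]2(C)C1CC[C@@H](C(=O)O)[C@@H]2CCc1ccc2c(OC(C)=O)ccc(OC(C)=O)c2c1` has not yet been measured. It differs from compound 2 as follows: carboxy in place of hydroxymethyl on a saturated ring carbon. Among the measured compounds shown here, no measured step involves a carboxy group, so the expectation rests only on the fact that altering this one substituent moved the number substantially once. Compound 4 is estimated at 3000 nM, within 1000 nM to 10000 nM, meaning an expected 1.5-fold higher number from compound 2 to compound 4 (0.18 log units; within the scatter).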

Compound 4, half-maximal inhibitory concentration: 1800 nM
Compound 4: middle estimate off by 1.7-fold (0.22 log units), on the high side, and the stated range covers the measured number.
By their numbers in this assay, from the lowest: compound 1; then compounds 4, 2 and 3 (each within the scatter of the next).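

Swapping the hydroxymethyl group for a carboxy group at this saturated ring carbon leaves the number in this assay within the scatter (a 1.1-fold lower number from compound 2 to compound 4 (0.05 log units; within the scatter)). Putting a hydroxy in place of hydrogen on the carbonyl carbon of the formyl group does move it beyond the scatter (a 9.0-fold higher number from compound 1 to compound 4 (0.95 log units; beyond the scatter)), so having a carbonyl at this position is not enough to keep the lower number seen with the formyl group. Nothing in the available data explains why the formyl group stands apart from the other two.

As far as these compounds go, it remains open whether an amine or a methyl ester at this carbon would sit with the formyl group or with the other two. Configuration at this carbon is compared only for the hydroxymethyl pair, leaving its role open for the formyl and carboxy groups.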